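Demethylation effect in the flavanonol series on nitrite output

The source may report more compounds than this note shows. Statements on the series, on what has been measured and on what is new or still open speak of the compounds shown alone.

Compound 2 `COc1ccc2c(c1)O[C@@H](c1cccc(O)c1O)[C@H](O)C2=O` gives 30300 nM in a functional assay on RAW264.7 cells (Rattus norvegicus) for inhibition, with RAW264.7 (Mus musculus) as the target, read by Griess assay, with stated times of 2 h and 16 h; on this read-out lower numbers stand for stronger inhibition and higher numbers for weaker inhibition. Compound 1 `O=C1c2ccc(O)cc2O[C@@H](c2cccc(O)c2O)[C@@H]1O` differs by hydrogen in place of methyl on an oxygen on an aromatic ring; its value in this assay, > 100000 nM, is a limit of the assay and not a number. The step of an at least 3.3-fold higher number from compound 2 to compound 1 (0.51 log units; beyond the scatter) therefore rests on (the limit of > 100000 nM in this assay, at which 2 of the 3 values shown sit). Compound 3 `COc1ccc2c(c1)C(=O)[C@@H](O)[C@H](c1cccc(O)c1O)O2` carries the same atoms as compound 2 joined differently; the difference between the two cores is not broken down here. For compound 3 the value > 100000 nM in this assay is again a limit. Compound 4 `O=C1c2cc(O)ccc2O[C@@H](c2cccc(O)c2O)[C@@H]1O` differs from compound 3 by hydrogen in place of methyl on an oxygen on an aromatic ring, the same change as from compound 2 to compound 1, at a place worded identically. Since compound 3 already sits at the limit of > 100000 nM in this assay, at which 2 of the 3 values shown sit, the expected step that the limit leaves unreadable from compound 3 to compound 4 in this assay is small and most likely another limit. Compound 4 is estimated at 150000 nM, with a range of 50000 nM to 500000 nM.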

Compound 4, half-maximal inhibitory concentration: > 100000 nM
Compound 4: a limit, no number (the forecaster's own chance of this, stated with the estimate: 85%); the middle value lies beyond the limit too.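

No step can be read from compound 3 to compound 4, because both sit at the same assay limit: the limit of > 100000 nM in this assay, at which 3 of the 4 values shown sit.

On these data alone, whether methoxy to hydroxy changes inhibition on the core of compound 3 stays open.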